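The compounds below may be only part of what the source reports. "The series", "measured", "known", "first", "only" and "open" are said of these compounds alone.

Compounds measured so far:
compound 1, `CC(C)(C)n1ncc(OCc2nnc(-c3cc(F)c(F)cc3F)o2)c(Cl)c1=O` — in a physicochemical assay for lipophilicity (on this read-out higher numbers stand for higher lipophilicity and lower numbers for lower lipophilicity), compound 1 gives 2.96
compound 2, `CC(C)(C)n1ncc(OCc2nnc(-c3ccc(F)cc3)o2)c(Cl)c1=O` — in this assay compound 2 gives 2.69
compound 3, `CC(C)(C)n1ncc(OCc2nnc(-c3ccccc3)o2)c(Cl)c1=O` — in this assay compound 3 gives 2.95

On the three numbers recorded in this assay, compound 1 sits at the top, but only nominally: its nearest neighbour is compound 3, which reads a number 0.01 log units lower from compound 1 to compound 3 (within the scatter), and the furthest is compound 2, at a number 0.27 log units lower from compound 1 to compound 2 (within the scatter). Both steps lie within the scatter of this kind of measurement, so the three compounds cannot be ordered on this read-out.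

The unmeasured compound 4, `CC(C)(C)n1ncc(OCc2nnc(-c3cc(F)c(Cl)cc3Cl)o2)c(Cl)c1=O`, is reached from compound 1 by a single change on the aromatic carbon of the five-membered ring: 2,4-dichloro-5-fluorophenyl in place of 2,4,5-trifluorophenyl on an aromatic carbon.

The two measured steps that touch the same aryl group, a number 0.27 log units lower from compound 1 to compound 2 (within the scatter) and a number 0.01 log units lower from compound 1 to compound 3 (within the scatter), show that exchanging fluorines for hydrogens on that ring moved nothing beyond the scatter. Going by the values given here, compound 4 instead exchanges two fluorines for two chlorines, a change none of the measured steps covers directly. The expectation for compound 4 in this assay is a moderate upward step, estimated as a number 0.54 log units higher from compound 1 to compound 4 (beyond the scatter). Compound 4 is therefore expected to give about 3.5, within a range from 3 to 4.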

Compound 4, partition coefficient: 3.36
Compound 4: middle estimate off by 0.14 log units, on the high side, and the stated range covers the measured number.
By their numbers in this assay, from the lowest: compounds 2, 3 and 1 (each within the scatter of the next); then compound 4.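

Going by these compounds alone, with the 2,4-dichloro-5-fluorophenyl group on this aromatic carbon of the five-membered ring, this assay gives the first steps that lie beyond the scatter (a number 0.40 log units higher from compound 1 to compound 4 (beyond the scatter); a number 0.41 log units higher from compound 3 to compound 4 (beyond the scatter); a number 0.67 log units higher from compound 2 to compound 4 (beyond the scatter)). Compound 1, compound 2 and compound 3 could not be ordered on this read-out, so among these four compounds, exchanging two fluorines for two chlorines moved the number clear of the scatter, whereas exchanging fluorines for hydrogens did not. No measurement shown bears on why the number moved.

As far as these compounds go, it remains open whether a single chlorine on this ring, at either of the two places it occupies in compound 4, would give part of this step. Also open, from the compounds shown here alone, is how an amine or a carboxylic acid at this position would read.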